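Relocating the Methoxy Group on the Pendant Ring

The compounds below may be only part of what the source reports. "The series", "measured", "known", "first", "only" and "open" are said of these compounds alone.

Going by the values given here, compound 2 `COc1ccccc1-c1cc(Oc2ccccc2)ccc1COC1CN(C#N)C1` holds the higher of the two numbers so far in an assay on isolated protein for inhibition of N-acylethanolamine-hydrolyzing acid amidase (Homo sapiens), read by fluorescence, with a stated time of 90 min (on this read-out lower numbers stand for stronger inhibition and higher numbers for weaker inhibition), where compound 2 gives 23.7 nM. Among the compounds with values here, its only measured neighbour is compound 1 `N#CN1CC(OCc2ccc(Oc3ccccc3)cc2-c2ccccc2)C1`, which in this assay gives 8.5 nM; the single measured step is a 2.8-fold higher number from compound 1 to compound 2 (0.45 log units; beyond the scatter). Compound 3 `COc1ccc(-c2cc(Oc3ccccc3)ccc2COC2CN(C#N)C2)cc1` differs from compound 2 by 4-methoxyphenyl in place of 2-methoxyphenyl on an aromatic carbon. Within the data shown here, no measured step exchanges one methoxyphenyl for another, so the only bearing comes from that step, which showed a modest cost on adding a methoxy group to the pendant ring. Whether the cost persists once the group is placed differently cannot be read from two values. Compound 3 is therefore expected to land near compound 2 or somewhat lower, a step of a 1.6-fold lower number from compound 2 to compound 3 (0.20 log units; within the scatter). The estimate for compound 3 in this assay is 15 nM, with a range from 5 nM to 50 nM.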

Compound 3, half-maximal inhibitory concentration: 5.7 nM
Compound 3: middle estimate off by 2.6-fold (0.42 log units), on the high side; the range from low to high includes it.
By their numbers in this assay, from the lowest: compounds 3 and 1 (each within the scatter of the next); then compound 2.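

In this assay, 4-methoxyphenyl in place of 2-methoxyphenyl gives a 4.2-fold lower number from compound 2 to compound 3 (0.62 log units; beyond the scatter), so the cost seen earlier does not follow from any methoxy group on the pendant ring, but from the 2-methoxyphenyl arrangement among the compounds shown. Against the phenyl group of the parent, the 4-methoxyphenyl group gives a 1.5-fold lower number from compound 1 to compound 3 (0.17 log units; within the scatter), so at this site, ortho to the ((1-cyanoazetidin-3-yl)oxy)methyl group and meta to the phenoxy group, the added methoxy group in this arrangement leaves the number unchanged within the scatter. Nothing available explains why the two arrangements part ways.

The compounds shown leave open whether a hydroxyl, an amine or a carboxylic acid in place of the methoxy group of 4-methoxyphenyl would hold this level. They also leave open whether a longer chain such as ethoxy would do so.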